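This account rests on a few compounds, and the source may have more. Where it says the series, first, only, none or still open, it means among the compounds named here.

Compound 1 `CC1CC/C(=N\Nc2ccccc2)c2ncc(C(=O)NN)c(=O)n21`: in a functional assay on the whole organism for inhibition, with Rattus norvegicus as the target (a higher number here means that more compound is needed for the effect, a lower number that less compound is needed), it is reported only as a limit, > 1000 umol/kg.
Compound 2 `CC1CC/C(=N\Nc2cccc(Cl)c2)c2ncc(C(=O)O)c(=O)n21`: in this assay compound 2 gives only a limit, > 100 umol/kg.
Compound 3 `C[C@@H]1CC/C(=N\Nc2ccc(O)cc2)c2ncc(C(=O)O)c(=O)n21`: in this assay compound 3 gives only a limit, > 100 umol/kg.

Compound 2 thus stands at a limit of this assay, not at a number; the three values shown sit at the limit of > 100 umol/kg in this assay, at which 2 of the 3 values shown sit, and at the limit of > 1000 umol/kg in this assay, at which 1 of the 3 values shown sits. Among the compounds with values here, no step between measured compounds differing in one place is available, so the move to compound 4 `Cc1ccc(N/N=C2\CCC(C)n3c2ncc(C(=O)O)c3=O)cc1`, (4-methylphenyl in place of 3-chlorophenyl on an amine nitrogen), starts from a limit with no measured trend to lean on. The expected step is none beyond the scatter, a step that the limit leaves unreadable from compound 2 to compound 4. Compound 4 is expected to be reported most probably again as a limit, with an estimated dose for half-maximal inhibition of 300 umol/kg, range 100 umol/kg to 1000 umol/kg.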

Compound 4, dose for 50% inhibition: > 1000 umol/kg
Compound 4 was reported as a limit; the forecaster's own chance of this, stated with the estimate: 75%; middle value at least 3.3-fold (0.52 log units) from the limit.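

Within the data shown here, compound 2 and compound 4 are both reported only as limits, and no step between them can be read. Whether 3-chlorophenyl and 4-methylphenyl on an amine nitrogen differ at all in this assay stays open; none of the compounds shown gives a number there.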